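Changing the aryl on the ring nitrogen: expected cytotoxicity

The source may report more compounds than this note shows. Statements on the series, on what has been measured and on what is new or still open speak of the compounds shown alone.

Three compounds sharing one core differ only in the aromatic group attached to an aromatic nitrogen. Compound 1 `COc1ccc(/C=C\C(=O)O)c(OCc2cn(-c3ccccc3F)nn2)c1CC=C(C)C` gives 11000 nM in a functional assay on T47D cells (Homo sapiens) for cytotoxicity, read by MTT assay, with a stated time of 24 h; a higher number here means a weaker inhibitor, a lower number a stronger inhibitor; compound 2 `COc1cccc(-n2cc(COc3c(/C=C\C(=O)O)ccc(OC)c3CC=C(C)C)nn2)c1` gives 20400 nM, and compound 3 `COc1ccc(/C=C\C(=O)O)c(OCc2cn(-c3ccc(CO)cc3)nn2)c1CC=C(C)C` gives 40000 nM, the highest of the three numbers. The steps among them are small: a 1.9-fold higher number from compound 1 to compound 2 (0.27 log units; within the scatter), a 3.6-fold higher number from compound 1 to compound 3 (0.56 log units; beyond the scatter), and a 2.0-fold higher number from compound 2 to compound 3 (0.29 log units; within the scatter). Compound 4 `COc1ccc(/C=C\C(=O)O)c(OCc2cn(-c3cccc([N+](=O)[O-])c3)nn2)c1CC=C(C)C` carries 3-nitrophenyl in place of 4-(hydroxymethyl)phenyl on an aromatic nitrogen. Every measured step is a change of that same aromatic group, and none went beyond a modest size, so only a small step is expected, if anything toward a lower number: a 1.6-fold lower number from compound 3 to compound 4 (0.20 log units; within the scatter). Compound 4 is therefore estimated at 25000 nM, with a range from 9000 nM to 70000 nM.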

Compound 4, half-maximal inhibitory concentration: 15400 nM
The estimate for compound 4 lay 1.6-fold (0.21 log units) above the measured number; low and high end bracket the measured number.
By their numbers in this assay, from the lowest: compounds 1, 4, 2 and 3 (each within the scatter of the next, the first and the last beyond it).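

Replacing 4-(hydroxymethyl)phenyl with 3-nitrophenyl gives a 2.6-fold lower number from compound 3 to compound 4 (0.41 log units; beyond the scatter), showing that this aromatic group can shift the number, though only modestly. The other steps are a 1.3-fold lower number from compound 2 to compound 4 (0.12 log units; within the scatter) for nitro in place of methoxy on an aromatic carbon and a 1.4-fold higher number from compound 1 to compound 4 (0.15 log units; within the scatter) for 3-nitrophenyl in place of 2-fluorophenyl, so compound 4 stays within the scatter of compounds 1 and 2 and only compound 3 separates from it. Nothing shown here explains these differences.

On these data alone, whether an amine or a carboxylic acid in place of the nitro group would shift the number remains open.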